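This account rests on a few compounds, and the source may have more. Where it says the series, first, only, none or still open, it means among the compounds named here.

Measured so far:
- compound 1, `CCCCCCNC(=O)n1cc(Cl)c(=O)[nH]c1=O`, gives 67 nM in an assay on HEK293 cells for inhibition of acid ceramidase (Rattus norvegicus), read by LC-MS, with a stated time of 30 min; a lower number here means a stronger inhibitor, a higher number a weaker inhibitor
- compound 2, `CCCCCCNC(=O)n1cc(F)c(=O)n(C(=O)C(C)C)c1=O`, gives 21 nM in this assay

Of these two numbers, compound 2 holds the lower one, and its gap to compound 1 is beyond the usual scatter of repeated measurements, so compound 2 counts as the stronger inhibitor of the pair. Compound 3, `CCCCCCNC(=O)n1cc(F)c(=O)n(C(=O)OCC(C)C)c1=O`, has not yet been measured. It differs from compound 2 in a single place: isobutoxy in place of isopropyl on a carbonyl carbon. Put another way, the isopropylcarbonyl attached to the core becomes an isobutoxycarbonyl; the hexyl chain and the rest of the core stay as they are. For the measured compounds named here, no measured pair shows this particular change, so there is nothing to calibrate it against. The expectation is a modest step in this assay, if any, with the number for compound 3 judged more likely to sit a little above that of compound 2 than below it. The estimated step from compound 2 to compound 3 is a 1.4-fold higher number from compound 2 to compound 3 (0.15 log units; within the scatter), which stays within the scatter. Compound 3 is therefore expected to give about 30 nM, with a range from 8 nM to 120 nM.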

Compound 3, half-maximal inhibitory concentration: 16 nM
For compound 3 the middle estimate is 1.9-fold (0.27 log units) above the measured one; low and high end bracket the measured number.
By their numbers in this assay, from the lowest: compounds 3 and 2 (each within the scatter of the next); then compound 1.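

Replacing isopropyl with isobutoxy on a carbonyl carbon gives a 1.3-fold lower number from compound 2 to compound 3 (0.12 log units; within the scatter) in this assay, so the two compounds cannot be told apart in this test. For the compounds shown here, this is the first sign of how much this position accepts: a group of 3 heavy atoms gives way to one of 5 heavy atoms, which also adds 1 hydrogen-bond acceptor and puts an oxygen on the carbonyl carbon, and the number stays within the normal spread of repeat measurements, although this single pair cannot show how far that tolerance extends. No measurement shown here explains why so large a change in the group leaves the number so little altered.

From the compounds shown here alone, whether a much longer chain, a benzyl group or an amine on the same carbonyl carbon would also leave the number in this range remains open, as one pair says nothing about groups of other shapes or charge. Going by these compounds, compound 1 differs from both other compounds in more than one place, so what the group on this carbonyl carbon contributes on its own, compared with the plain amide hydrogen on an otherwise identical fluoro compound, also remains unknown.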